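Changing the group on the carbonyl carbon of compound 1

The source may report more compounds than this note shows. Statements on the series, on what has been measured and on what is new or still open speak of the compounds shown alone.

Compound 1 `Cc1nc(S(C)(=O)=O)ccc1Oc1ncnc(OC2CCN(C(=O)OC3COC3)CC2)c1F` gives 326 nM in a functional assay on isolated protein for inhibition of Glucose-dependent insulinotropic receptor (Homo sapiens), read by HTRF and cAMP accumulation; on this read-out higher numbers stand for an effect only at larger amounts of compound and lower numbers for an effect already at smaller amounts.
Compound 2 `Cc1nc(S(C)(=O)=O)ccc1Oc1ncnc(OC2CCN(C(=O)SC(C)C)CC2)c1F` gives 6.8 nM in this assay.
Compound 3 `Cc1nc(S(C)(=O)=O)ccc1Oc1ncnc(OC2CCN(C(=S)OC(C)C)CC2)c1F` gives 69.9 nM in this assay.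

Compound 1 stands highest of the three numbers in this assay; its nearest neighbour is compound 3 and its furthest is compound 2. Compound 4 `Cc1nc(S(C)(=O)=O)ccc1Oc1ncnc(OC2CCN(C(=O)C3(C)CC3)CC2)c1F` has not yet been measured. It differs from compound 1 in one place: 1-methylcyclopropyl in place of (oxetan-3-yl)oxy on a carbonyl carbon.

Within the data shown here, two measured steps bear on this change, since both replace the (oxetan-3-yl)oxy group on the same carbonyl carbon of compound 1. The first is a 48-fold lower number from compound 1 to compound 2 (1.68 log units; beyond the scatter), the second is a 4.7-fold lower number from compound 1 to compound 3 (0.67 log units; beyond the scatter). Both point the same way, to lower numbers, though they differ greatly in size, and a 10-fold higher number from compound 2 to compound 3 (1.01 log units; beyond the scatter) shows how much the group at this position alone can move the read-out. Neither replacement is the 1-methylcyclopropyl group itself, so the size of the step for compound 4 is uncertain, but the direction in this assay is expected to be downward and beyond the scatter.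

Compound 4 is therefore estimated at 30 nM, with a likely range from 8 nM to 120 nM, which would be a step of an 11-fold lower number from compound 1 to compound 4 (1.04 log units; beyond the scatter).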

Compound 4, half-maximal effective concentration: 761 nM
For compound 4 the middle estimate is 25-fold (1.40 log units) below the measured one, outside the stated range (above it).
By their numbers in this assay, from the lowest: compound 2; then compound 3; then compound 1; then compound 4.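

In this assay, the step of a 2.3-fold higher number from compound 1 to compound 4 (0.37 log units; beyond the scatter) runs upward, so a replacement of (oxetan-3-yl)oxy on this carbonyl carbon does not always lead to a lower number, as the two earlier steps had suggested. The range at this position also widens, with a 110-fold higher number from compound 2 to compound 4 (2.05 log units; beyond the scatter) and an 11-fold higher number from compound 3 to compound 4 (1.04 log units; beyond the scatter), both large, leaving compound 4 with the highest number of the four and showing that the read-out depends strongly on which group enters here, not merely on the removal of (oxetan-3-yl)oxy. No measurement beyond these numbers is available to explain the change of direction.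

The compounds shown leave open whether the 1-methylcyclopropyl ring itself or the absence of an oxygen or sulfur atom joining the group to the carbonyl carbon sets compound 4 apart from compound 2 and compound 3. An isopropyl or isopropoxy group on the same carbonyl carbon would help separate these possibilities, and the isopropoxy group would also show how the sulfur-containing groups of compound 2 and compound 3 compare with their all-oxygen counterpart.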